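Vinyl in place of hydrogen on a shared core

The source may hold more compounds than are shown below. What is called first, only, known or untested is meant among the compounds shown, and "the series" means these compounds.

Measured compounds, with their half-maximal inhibitory concentrations:
compound 1 `c1ccc(-c2nc(-c3c[nH]c4ccccc34)co2)cc1`, 113000 nM
compound 2 `Oc1ccc(-c2nc(-c3c[nH]c4ccccc34)co2)cc1`, 103000 nM
compound 3 `c1ccc2c(-c3cocn3)c[nH]c2c1`, 103000 nM

In a functional assay on MIA PaCa-2 cells (Homo sapiens) for cytotoxicity, read by MTT assay, with a stated time of 48 h (a lower number here means a stronger inhibitor, a higher number a weaker inhibitor), compound 3 gives 103000 nM. This is level with compound 2 at the digits shown, and the two together hold the lowest numbers of the three, while compound 1, at 113000 nM, sits only a hair away: a 1.1-fold lower number from compound 1 to compound 3 (0.04 log units; within the scatter), and no change at the digits printed from compound 2 to compound 3 (within the scatter).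

Compound 4 `C=Cc1nc(-c2c[nH]c3ccccc23)co1` takes the same core and carries one change: vinyl in place of hydrogen on an aromatic carbon. The new group sits on an aromatic carbon of the five-membered ring with one nitrogen and one oxygen, next to the ring nitrogen and next to the ring oxygen, two ring bonds from the ring atom that bears the nine-heavy-atom group.

The measured steps that bear on this position are the removal of phenyl, a 1.1-fold lower number from compound 1 to compound 3 (0.04 log units; within the scatter), and the swap of hydrogen for hydroxy on that phenyl, a 1.1-fold lower number from compound 1 to compound 2 (0.04 log units; within the scatter). Both fell within the scatter, so this carbon has so far tolerated a large group or none with no visible effect on this assay. A vinyl group is smaller than either aryl group tried, and nothing in the three numbers points to a direction. The expected step is therefore none beyond the scatter: a 1.0-fold higher number from compound 3 to compound 4 (0.01 log units; within the scatter).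

Compound 4 is estimated at 105000 nM, within a range of 50000 nM to 220000 nM.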

Compound 4, half-maximal inhibitory concentration: 37600 nM
Estimate against measurement, compound 4: 2.8-fold (0.45 log units) above, outside the stated range (below it).
By their numbers in this assay, from the lowest: compound 4; then compounds 2, 3 and 1 (each within the scatter of the next).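

For the compounds shown here, on the shared core, hydrogen, phenyl and 4-hydroxyphenyl at this carbon all gave numbers within the scatter of one another, which made the position look indifferent to its group, but vinyl is the first group here to move the number in this assay (a 2.7-fold lower number from compound 3 to compound 4 (0.44 log units; beyond the scatter)). The same holds against both aryl groups (a 2.7-fold lower number from compound 2 to compound 4 (0.44 log units; beyond the scatter); a 3.0-fold lower number from compound 1 to compound 4 (0.48 log units; beyond the scatter)), so this carbon does respond to what it carries, and the response does not follow heavy-atom count in a simple line, as vinyl stands apart from both the hydrogen and the larger aryl groups. The data shown include no separate measurement that accounts for this step.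

The compounds shown leave open whether the double bond itself matters or any short chain would do the same, a question that an ethyl group, with the same two carbons and no double bond, would address. They also leave open whether the step grows or disappears with a longer chain such as propenyl, or with an amine or a carboxylic acid at the same carbon.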